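Oxan-4-yl in place of cyclopentyl on the shared core

The compounds below may be only part of what the source reports. "The series", "measured", "known", "first", "only" and "open" are said of these compounds alone.

In a physicochemical assay for solubility, using the shake flask method, in phosphate buffer, measured as kinetic solubility, with a stated time of 20 h, at pH 6.5 (on this read-out higher numbers stand for higher solubility and lower numbers for lower solubility), compound 1 (`O=C(O)c1ccc(Nc2cc3[nH]c(-c4cccc(C(F)(F)F)c4)nc3cn2)nc1`) gives 6000 nM. Compound 2 (`FC(F)(F)c1ccc(Nc2cc3[nH]c(C4CCCC4)nc3cn2)nc1`) gives 145000 nM, the higher of the two numbers and beyond the scatter from the other. Within the data shown here, these two compounds differ in more than one place, so no measured step isolates the change at hand. Compound 3 (`FC(F)(F)c1ccc(Nc2cc3[nH]c(C4CCOCC4)nc3cn2)nc1`) carries oxan-4-yl in place of cyclopentyl on an aromatic carbon. A small upward change within the scatter is expected, with the estimated step of a 1.4-fold higher number from compound 2 to compound 3 (0.14 log units; within the scatter). Compound 3 is estimated at 200000 nM, with an expected range of 70000 nM to 500000 nM.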

Compound 3, solubility: 155000 nM
Beside the measured number, compound 3's estimate is 1.3-fold (0.11 log units) above it; low and high end bracket the measured number.
By their numbers in this assay, from the lowest: compound 1; then compounds 2 and 3 (each within the scatter of the next).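

On the shared core, oxan-4-yl in place of cyclopentyl on an aromatic carbon reads in this assay as a 1.1-fold higher number from compound 2 to compound 3 (0.03 log units; within the scatter) and so stays within the scatter. Among these compounds, at this position, between two ring nitrogen atoms, the first single-place comparison leaves compound 2 and compound 3 indistinguishable on this read-out, despite the added ring oxygen and hydrogen-bond acceptor. No supporting data bear on this result. Still open, from the compounds shown here alone, is whether an amine or a longer alkyl chain at this position would separate from compound 2 beyond the scatter.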